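Swapping the aryl cap on a triazole-linked cinnamic acid series

The compounds below may be only part of what the source reports. "The series", "measured", "known", "first", "only" and "open" are said of these compounds alone.

Measured compounds:
- Compound 1, `COc1ccc(/C=C\C(=O)O)c(OCc2cn(-c3ccc(NC(=O)c4ccccc4)cc3)nn2)c1CC=C(C)C`: 23300 nM
- Compound 3, `COc1ccc(/C=C\C(=O)O)c(OCc2cn(-c3ccccc3C(=O)N3CCC(O)C3)nn2)c1CC=C(C)C`: 13400 nM
- Compound 2, `COc1ccc(-n2cc(COc3c(/C=C\C(=O)O)ccc(OC)c3CC=C(C)C)nn2)cc1`: "not determined" (no result reported)

All three share one core and differ only in the aryl group attached to the triazole nitrogen. In a functional assay on T47D cells (Homo sapiens) for cytotoxicity, read by MTT assay, with a stated time of 24 h (a lower number here means a stronger inhibitor, a higher number a weaker inhibitor), compound 1 gives 23300 nM and compound 3 gives 13400 nM. For compound 2, which carries a 4-methoxyphenyl at that position, this assay reports no single number, so its place among the others cannot be fixed from the data at hand.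

Compound 4, `COc1ccc(/C=C\C(=O)O)c(OCc2cn(-c3cccc([N+](=O)[O-])c3)nn2)c1CC=C(C)C`, is the next point. Compared with compound 2 it shows the change (3-nitrophenyl in place of 4-methoxyphenyl on an aromatic nitrogen), that is, 3-nitrophenyl in place of 4-methoxyphenyl on an aromatic nitrogen. For the measured compounds named here, no measured pair in this set isolates that change, so no size can be read from the numbers for it; the two values that do exist, from compound 1 and compound 3, sit close together and are the only anchor.

On that basis, compound 4 is expected to land near those two, at an estimated 18000 nM with a range of 6000 nM to 60000 nM in this assay.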

Compound 4, half-maximal inhibitory concentration: 15400 nM
Beside the measured number, compound 4's estimate is 1.2-fold (0.07 log units) above it; the measured number falls inside the stated range.
By their numbers in this assay, from the lowest: compounds 3, 4 and 1 (each within the scatter of the next).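

For the compounds shown here, compound 2 has no single number in this assay, so no step to compound 4 can be read from this result. As far as these compounds go, how much the 3-nitrophenyl group itself shifts the value of compound 4 stays open, and no supporting evidence on hand bears on this result.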